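A few compounds are considered here, and "the series" means these few. Any claim that something is new, unique, unknown or untested is made for them only; others in the source may bear on it.

Measured so far in a functional assay on HeLa cells (Homo sapiens) for antiproliferative activity, read by MTT assay, with a stated time of 72 h; a higher number here means a weaker inhibitor, a lower number a stronger inhibitor:
- compound 1 `O=C1O[C@H]([C@@H](O)Cn2cc(CNS(=O)(=O)c3ccc(F)cc3)nn2)C(OCc2ccccc2)=C1OCc1ccccc1` gives 25000 nM
- compound 2 `COc1ccccc1-c1cn(C/C=C2\OC(=O)C(OCc3ccccc3)=C2OCc2ccccc2)nn1` gives > 100000 nM, which is a limit of this assay rather than a number
- compound 3 `O=C1O/C(=C\Cn2cc(-c3cccc(O)c3)nn2)C(OCc2ccccc2)=C1OCc1ccccc1` gives 74800 nM

Of the two numbers, compound 1 has the lower one, and compound 3 sits higher by more than the usual scatter. For the measured compounds named here, the only measured step, an at least 1.3-fold lower number from compound 2 to compound 3 (0.12 log units; that floor lies within the scatter), alters the aromatic group on the triazole and is within the scatter.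

Compound 4 `O=C1O[C@H]([C@@H](O)Cn2cc(CCO)nn2)C(OCc2ccccc2)=C1OCc1ccccc1` differs from compound 1 by hydroxymethyl in place of ((4-fluorophenyl)sulfonyl)amino on a saturated chain carbon bound to an aromatic carbon. Going by the values given here, none of the measured steps touches this part of the molecule, so no measured step bears on the change. With nothing to anchor it, compound 4 is expected to give a higher number, with a wide range and a real chance of only a limit: the expected step is a 2.0-fold higher number from compound 1 to compound 4 (0.30 log units; within the scatter), and the estimate for compound 4 is 50000 nM (from 15000 nM to 200000 nM).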

Compound 4, half-maximal inhibitory concentration: 68800 nM
Estimate against measurement, compound 4: 1.4-fold (0.14 log units) below; measured number inside the range.
By their numbers in this assay, from the lowest: compound 1; then compounds 4 and 3 (each within the scatter of the next). At a limit, above all of these: compound 2.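

Replacing ((4-fluorophenyl)sulfonyl)amino with hydroxymethyl on this saturated chain carbon gives a 2.8-fold higher number from compound 1 to compound 4 (0.44 log units; beyond the scatter), so the number does respond to this group, though modestly. The earlier step changed only the aromatic group on the triazole and could not show this. Nothing available explains why the larger group gives the lower number. On these data alone, it remains open whether the fluorine, the sulfonyl or the aromatic ring of the leaving group matters most. As far as these compounds go, an amine, a carboxylic acid or a longer chain at this place also remains untested here.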